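The source may report more compounds than this note shows. Statements on the series, on what has been measured and on what is new or still open speak of the compounds shown alone.

Measured compounds in a functional assay on L1210 cells (Mus musculus) for antiproliferative activity; on this read-out lower numbers stand for stronger inhibition and higher numbers for weaker inhibition:
compound 1, `COc1cc(C(=O)c2sc(-c3ccc(C)cc3)cc2N)cc(OC)c1OC` — 18 nM
compound 2, `COc1cc(C(=O)c2sc(-c3ccc(Cl)cc3)cc2N)cc(OC)c1OC` — 93 nM
compound 3, `COc1cc(C(=O)c2sc(-c3ccc(C(F)(F)F)cc3)cc2N)cc(OC)c1OC` — 370 nM

Compound 3 gives the highest number of the three: a 21-fold higher number from compound 1 to compound 3 (1.31 log units; beyond the scatter) and a 4.0-fold higher number from compound 2 to compound 3 (0.60 log units; beyond the scatter). Among the measured compounds shown here, the series so far varies only the group on an aromatic carbon of the six-membered ring, para to a large group, and the number rises along methyl, chloro, trifluoromethyl.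

Compound 4, `CCOc1ccc(-c2cc(N)c(C(=O)c3cc(OC)c(OC)c(OC)c3)s2)cc1`, continues at the same place: ethoxy in place of trifluoromethyl on an aromatic carbon. For the measured compounds named here, the steps that bear on this are the two that end at compound 3, a 21-fold higher number from compound 1 to compound 3 (1.31 log units; beyond the scatter) and a 4.0-fold higher number from compound 2 to compound 3 (0.60 log units; beyond the scatter); both show that exchanging the group at this position moves this assay well beyond the scatter, and that trifluoromethyl sits at the weak end. Ethoxy is new to the series, so no measured step gives its direction directly; the expectation is that replacing trifluoromethyl sends the number back down, toward the range of compound 1 and compound 2 rather than beyond it. Compound 4 is therefore expected at 35 nM, within 10 nM to 150 nM, an expected step of an 11-fold lower number from compound 3 to compound 4 (1.02 log units; beyond the scatter).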

Compound 4, half-maximal inhibitory concentration: 590 nM
The estimate for compound 4 lay 17-fold (1.23 log units) below the measured number; measured number above the stated range.
By their numbers in this assay, from the lowest: compound 1; then compound 2; then compounds 3 and 4 (each within the scatter of the next).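

In this assay, ethoxy on this aromatic carbon, para to a large group, reads level with trifluoromethyl (a 1.6-fold higher number from compound 3 to compound 4 (0.20 log units; within the scatter)), so the weak end of the series now holds two groups with different atoms, one with no hydrogen-bond acceptor and one with a single acceptor. Ethoxy also stands well away from the other two groups (a 6.3-fold higher number from compound 2 to compound 4 (0.80 log units; beyond the scatter); a 33-fold higher number from compound 1 to compound 4 (1.52 log units; beyond the scatter)), which leaves methyl as the only group in the low range and chloro in an intermediate place. Nothing available explains why these two different groups give such similar numbers.

Going by these compounds, whether the high number of compound 4 follows the oxygen or the two-carbon chain stays open, and methoxy and ethyl at this position would separate the two. On these data alone, how an amine or a hydroxyl group would read in this assay also stays open.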